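The source may report more compounds than this note shows. Statements on the series, on what has been measured and on what is new or still open speak of the compounds shown alone.

Measured so far in a functional assay on Raji cells (Homo sapiens) for antiproliferative activity, read by CCK-8 assay, with a stated time of 72 h, tested at 40 uM; on this read-out higher numbers stand for more inhibition at the one concentration tested (going by the name of the read-out) and lower numbers for less inhibition:
- compound 1 `CN1CCN(c2ccc(Nc3nc(-c4cccc(NC(=O)c5ccc(F)cc5)c4)sc3C(N)=O)cc2)CC1` gives 95.3%
- compound 2 `CN1CCN(c2ccc(Nc3nc(-c4cccc(NC(=O)c5ccc(C(F)(F)F)cn5)c4)sc3C(N)=O)cc2)CC1` gives 84.6%

Among the compounds with values here, compound 2 stands lowest of the two numbers in this assay; the only other number, that of compound 1, is separated from it by a number 10.7 percentage points lower from compound 1 to compound 2 (beyond the scatter), a step beyond the scatter.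

Compound 3 `CN1CCN(c2ccc(Nc3nc(-c4cccc(NC(=O)c5ccco5)c4)sc3C(N)=O)cc2)CC1` is the next compound to be run in this assay. Its change from compound 2 is furan-2-yl in place of 5-(trifluoromethyl)pyridin-2-yl on a carbonyl carbon. Within the data shown here, one measured step bears on this change, since it also swaps the group on the same carbonyl carbon: a number 10.7 percentage points lower from compound 1 to compound 2 (beyond the scatter), a modest fall. Among the measured compounds shown here, no step involving furan-2-yl has been measured, so the direction of the new swap cannot be read from the numbers at hand; a step of similar modest size in either direction, or none beyond the scatter, is what is expected. Compound 3 is therefore estimated at 85% in this assay, with a range of 65% to 97%. This estimate means an expected step of a number 0.4 percentage points higher from compound 2 to compound 3 (within the scatter).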

Compound 3, a percentage reported as inhibition, at one concentration (the size of the read-out at that concentration, not a potency): 84.3%
Compound 3: middle estimate off by 0.7 percentage points, on the high side; the measured number falls inside the stated range.
By their numbers in this assay, from the lowest: compounds 3 and 2 (each within the scatter of the next); then compound 1.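

In this assay, the group on the carbonyl carbon whose other neighbour is the amide-type nitrogen goes from 10 heavy atoms to 5, and from a six-membered to a five-membered aromatic ring, with a number 0.3 percentage points lower from compound 2 to compound 3 (within the scatter) as the result, so neither the trifluoromethyl group nor the larger ring separates compound 2 from compound 3 on this read-out. Set against the 4-fluorophenyl group, furan-2-yl gives a number 11 percentage points lower from compound 1 to compound 3 (beyond the scatter), a step that sits alongside a number 10.7 percentage points lower from compound 1 to compound 2 (beyond the scatter) and leaves compound 1 as the one compound of the three standing apart from the others, with compound 2 and compound 3 level within the scatter. Nothing measured in the series accounts for these numbers or for the position of compound 1.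

Going by these compounds, whether a non-aromatic group on the carbonyl carbon, such as a cyclohexyl ring, a short alkyl chain or a morpholine, gives a higher, lower or level number remains open, as does the effect of moving the fluorine on the phenyl ring. On these data alone, all three compounds also give high inhibition at the single concentration of this assay, so their relative potency stays open, and full concentration-response data would be needed to settle it.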